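The source may hold more compounds than are shown below. What is called first, only, known or untested is meant among the compounds shown, and "the series" means these compounds.

Values in a physicochemical assay for solubility, measured as kinetic solubility, at pH 6.5; a higher number here means a more soluble compound, a lower number a less soluble compound:
- compound 1 `C[C@@H](c1ccc2ncccc2c1)c1nnc2ccc(-c3cccc(C#N)c3)nn12`: 32500 nM
- compound 2 `CN(C)c1ccc2nnc(Cc3ccc4ncccc4c3)n2n1`: 134000 nM
- compound 3 `COc1ccc(-c2ccc3nnc([C@@H](C)c4ccc5ncccc5c4)n3n2)cc1F`: 10900 nM

Of these three numbers, compound 3 has the lowest in this assay, with compound 1 the nearest and compound 2 the furthest. Compound 2 differs from compound 3 in more than one place, so its value says little about the next change.

Among the measured compounds shown here, that change leads to compound 4 `COc1ccc(-c2ccc3nnc([C@@H](C)c4ccc5ncccc5c4)n3n2)cc1C`, the one compound still unmeasured. The edit is methyl in place of fluoro on an aromatic carbon. The aryl group thus goes from 3-fluoro-4-methoxyphenyl to 4-methoxy-3-methylphenyl, and the rest of the structure stays the same.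

For the measured compounds named here, only one measured step touches this aryl group: a 3.0-fold lower number from compound 1 to compound 3 (0.47 log units; beyond the scatter). That step is modest, though beyond the scatter, and it replaces 3-cyanophenyl with 3-fluoro-4-methoxyphenyl. It does not exchange fluoro for methyl, so no measurement here tests this swap directly. A step smaller than that one is therefore expected, most likely within the scatter. From the compounds shown here alone, a slightly lower number is the tentative expectation, but the direction remains open.

The expected change is a 1.3-fold lower number from compound 3 to compound 4 (0.11 log units; within the scatter). For compound 4 the estimated value is 8500 nM, with an expected range from 4000 nM to 18000 nM.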

Compound 4, solubility: 1770 nM
Beside the measured number, compound 4's estimate is 4.8-fold (0.68 log units) above it, and the stated range ends above it.
By their numbers in this assay, from the lowest: compound 4; then compound 3; then compound 1; then compound 2.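

In this assay, the aryl position ortho to a methoxy group proves responsive to an exchange of one heavy atom for another: methyl in place of fluoro gives a 6.2-fold lower number from compound 3 to compound 4 (0.79 log units; beyond the scatter) and leaves the rest of the structure unchanged. Among the compounds shown here, the earlier compounds could not show this, since their only step touching this aryl group replaced the whole group and so could not single out this substituent. Measured against the 3-cyanophenyl group of compound 1, the 4-methoxy-3-methylphenyl group gives an 18-fold lower number from compound 1 to compound 4 (1.26 log units; beyond the scatter) and this large step shows how far the aryl group alone can move the number while the core and the chiral methyl-bearing link stay the same.

The compounds shown leave open whether this drop is particular to methyl or would also appear with a chlorine atom, an ethyl group or an amine at the same position, and whether it would persist with the methoxy group removed. Nothing available here accounts for the size of the drop.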